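Bromo substitution on the benzyl ring of compound 1

A few compounds are considered here, and "the series" means these few. Any claim that something is new, unique, unknown or untested is made for them only; others in the source may bear on it.

Within the data shown here, compound 1 `COc1cc(OC)c(-c2coc3cc(OCc4ccccc4)ccc3c2=O)cc1OC` is one of three compounds measured in a functional assay on U-251 cells (Homo sapiens) for antiproliferative activity, read by MTT assay, with a stated time of 24 h; a lower number here means a stronger inhibitor, a higher number a weaker inhibitor; in that assay compound 1 gives 6750 nM. It stands second highest of the three numbers. Its nearest neighbour is compound 2 `COc1ccc2c(=O)c(-c3cc(OC)c(OC)cc3OC)coc2c1`, which gives 9400 nM; the step of a 1.4-fold higher number from compound 1 to compound 2 (0.14 log units; within the scatter) is within the scatter. Furthest away is compound 3 `COc1cc(OC)c(-c2coc3cc(OCc4ccccc4F)ccc3c2=O)cc1OC`, which gives 2890 nM; the step of a 2.3-fold lower number from compound 1 to compound 3 (0.37 log units; beyond the scatter) is modest but beyond the scatter, as is the step of a 3.3-fold lower number from compound 2 to compound 3 (0.51 log units; beyond the scatter).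

Compound 4 `COc1cc(OC)c(-c2coc3cc(OCc4ccc(Br)cc4)ccc3c2=O)cc1OC` is not yet measured. It differs from compound 1 as follows: bromo in place of hydrogen on an aromatic carbon. The nearest analogy among the measured steps is the step from compound 1 to compound 3, where fluoro in place of hydrogen on an aromatic carbon of the same benzyl ring gave a 2.3-fold lower number from compound 1 to compound 3 (0.37 log units; beyond the scatter). Bromo is a different halogen and sits on a different carbon of that ring, so the analogy is loose, and no measured step tests bromo directly.

On that basis a modest lowering of the number is expected for compound 4, with the step estimated as a 1.7-fold lower number from compound 1 to compound 4 (0.23 log units; within the scatter), though a result within the scatter of compound 1 would not surprise. The estimate for compound 4 in this assay is 4000 nM, with a range from 1800 nM to 9000 nM.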

Compound 4, half-maximal inhibitory concentration: 10000 nM
The estimate for compound 4 lay 2.5-fold (0.40 log units) below the measured number, and the stated range ends below it.
By their numbers in this assay, from the lowest: compound 3; then compounds 1, 2 and 4 (each within the scatter of the next).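

In this assay, the 4-bromobenzyl group does not repeat the lowering seen with the 2-fluorophenyl change: compound 4 stays within the scatter of compound 1 (a 1.5-fold higher number from compound 1 to compound 4 (0.17 log units; within the scatter)) and of compound 2 (a 1.1-fold higher number from compound 2 to compound 4 (0.03 log units; within the scatter)). A halogen on the benzyl ring is therefore not enough by itself, and among the halogen-bearing compounds only compound 3 stands apart from compound 4 (a 3.5-fold higher number from compound 3 to compound 4 (0.54 log units; beyond the scatter)). No measurement here bears on the reason for this gap.

Compound 3 and compound 4 differ in both the halogen and its carbon on the ring, so the compounds shown leave open which of the two follows the gap. Also open, on these data alone, is how chloro, an amine or a carboxylic acid on the same ring would read.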